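The compounds below may be only part of what the source reports. "The series", "measured", "known", "first", "only" and "open" are said of these compounds alone.

Measured so far:
- compound 1, `Cc1ccc(-c2ccccc2NCC2=NCCN2)n1C`: 50.1 nM
- compound 2, `CCCCn1ncnc1-c1ccccc1NCC1=NCCN1`: 200 nM

Both numbers come from an in vitro functional assay on cells (Fibroblast) for agonist activity at Alpha-1A adrenergic receptor (Homo sapiens); a lower number here means that less compound is needed, a higher number that more compound is needed for the effect. Compound 1 gives 50.1 nM and stands lowest of the two; the nearest is compound 2, whose value of 200 nM lies beyond the scatter above it. For the measured compounds named here, no step between the two has been worked out, as they differ in more than one place, so only the two values themselves are compared here.

The next compound, compound 3, `Cn1cccc1-c1ccccc1NCC1=NCCN1`, has not yet been measured in this assay. It differs from compound 1 in one place: hydrogen in place of methyl on an aromatic carbon. The group that leaves is the methyl on the aromatic carbon of the five-membered aromatic ring with 1 nitrogen, next to the ring nitrogen; the rest of the shared core is untouched.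

With no measured step of this kind in the series, the expectation rests on the small size of the change. A move of modest size is expected, if anything toward a higher number, and it may well remain within the scatter. Compound 3 is estimated at 80 nM, with a range from 30 nM to 250 nM, which means an expected step of a 1.6-fold higher number from compound 1 to compound 3 (0.20 log units; within the scatter).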

Compound 3, half-maximal effective concentration: 20 nM
Estimate against measurement, compound 3: 4.0-fold (0.60 log units) above; the measured number lies below the stated range.
By their numbers in this assay, from the lowest: compound 3; then compound 1; then compound 2.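

For the compounds shown here, replacing the methyl with hydrogen on this aromatic carbon of the five-membered aromatic ring with 1 nitrogen, next to the ring nitrogen, gives a 2.5-fold lower number from compound 1 to compound 3 (0.40 log units; beyond the scatter) in this assay, the first step that isolates a single place. The methyl at this position is therefore not required for agonist activity at this level of potency, and removing this single carbon lowers the number rather than raising it, so this carbon tolerates the loss of its substituent. No measurement available here accounts for the direction or size of this step.

From the compounds shown here alone, at this carbon, the comparison covers only methyl and hydrogen, so it remains open whether an ethyl group, a chlorine atom or a methoxy group would fall on the side of the methyl or of the hydrogen, or beyond either. Also open, going by these compounds, is what happens when the methyl on the ring nitrogen, which compound 1 and compound 3 share, gives way to hydrogen or a longer chain.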